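Series notes: aryl swap on the fused thiophene core

The source may report more compounds than this note shows. Statements on the series, on what has been measured and on what is new or still open speak of the compounds shown alone.

For the measured compounds named here, compound 2 `CNc1nc(NCCCN(C)C)c2sc(-c3ccc(OC)nc3)cc2n1` is the higher of the two numbers so far in a physicochemical assay for lipophilicity, read by HPLC, at pH 7.4; on this read-out higher numbers stand for higher lipophilicity and lower numbers for lower lipophilicity: in this assay compound 2 gives 2.8. Its nearest neighbour is compound 1 `CNc1nc(NCCCN(C)C)c2sc(-c3ccc(NS(C)(=O)=O)cc3)cc2n1`, which in this assay gives 2.1, a gap beyond the usual scatter. Going by the values given here, no pair that differs in only one place has been measured, so the two values can be compared but not read as a single step.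

Compound 3 `CNc1nc(NCCCN(C)C)c2sc(-c3ccc(C(C)=O)cc3)cc2n1` is the next candidate for this assay. It differs from compound 2 by 4-acetylphenyl in place of 6-methoxypyridin-3-yl on an aromatic carbon; in short, 4-acetylphenyl in place of 6-methoxypyridin-3-yl on an aromatic carbon. Among the compounds with values here, with no measured one-place step to lean on, the expectation rests on the two values above: the change is expected to move lipophilicity by a small amount at most, if anything slightly upward, with the step from compound 2 to compound 3 estimated at a number 0.10 log units higher from compound 2 to compound 3 (within the scatter). On that basis compound 3 is expected to give about 2.9 in this assay, with a plausible range from 2.4 to 3.4.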

Compound 3, distribution coefficient: 2.9
Beside the measured number, compound 3's estimate shows no gap at the digits printed; measured number inside the range.
By their numbers in this assay, from the lowest: compound 1; then compounds 2 and 3 (each within the scatter of the next).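

In this assay, 4-acetylphenyl in place of 6-methoxypyridin-3-yl, on the aromatic carbon next to the ring sulfur, gives a number 0.10 log units higher from compound 2 to compound 3 (within the scatter), so exchanging a ring with one hetero atom for a ring of carbon only does not separate the two compounds on this read-out. The series also gains a second one-place comparison: acetyl in place of methanesulfonamido on an aromatic carbon gives a number 0.80 log units higher from compound 1 to compound 3 (beyond the scatter), which shows that at this level of the structure a change of substituent can move the number past the scatter, whereas the ring exchange between compound 2 and compound 3 does not. Nothing measured here bears on why either step has the size it has.

Going by these compounds, whether a carboxylic acid, a primary amide or a nitrile in place of acetyl would stay with compound 3 or fall toward compound 1 remains open. Equally open, on these data alone, is whether these steps hold if a morpholine replaces the dimethylamino group of the shared chain.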